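Moving the bromine on the aryl group of compound 3

A few compounds are considered here, and "the series" means these few. Any claim that something is new, unique, unknown or untested is made for them only; others in the source may bear on it.

Three analogues of one core have been measured in a functional assay on CHO cells for agonist activity at adenosine receptor A1 (Homo sapiens), read by fluorescence and ERK phosphorylation, with stated times of 30 min and 1.5 h, tested at 3 uM; on this read-out lower numbers stand for a weaker effect and higher numbers for a stronger effect at the one concentration tested. Compound 1 `Nc1scc(-c2ccc(F)cc2)c1C(=O)c1ccccc1` gives 51%, compound 2 `Nc1scc(-c2ccc(Cl)cc2)c1C(=O)c1ccccc1` gives 46%, and compound 3 `Nc1scc(-c2cccc(Br)c2)c1C(=O)c1ccccc1` gives 67%. Compound 3 stands highest of the three, with its nearest neighbour compound 1 and compound 2 furthest; both gaps lie beyond the scatter. Between compound 1 and compound 2 the step is a number 5 percentage points lower from compound 1 to compound 2 (within the scatter).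

Compound 4 `Nc1scc(-c2ccc(Br)cc2)c1C(=O)c1ccccc1` differs from compound 3 in one place: 4-bromophenyl in place of 3-bromophenyl on an aromatic carbon. Among the compounds with values here, the steps that bear on this are a number 16 percentage points higher from compound 1 to compound 3 (beyond the scatter) and a number 21 percentage points higher from compound 2 to compound 3 (beyond the scatter); each pairs a 4-halophenyl with the 3-bromophenyl, though the halogen also changes there, so neither isolates the position of the bromine. Since both 4-halophenyl compounds sit lower than compound 3, a drop in this assay is expected for compound 4, of a size estimated as a number 14 percentage points lower from compound 3 to compound 4 (beyond the scatter). Compound 4 is therefore estimated at 53%, with a range from 38% to 68%.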

Compound 4, a percentage reported as activity, at one concentration (the size of the read-out at that concentration, not a potency): 46%
Estimate against measurement, compound 4: 7 percentage points above; the measured number falls inside the stated range.
By their numbers in this assay, from the lowest: compounds 2, 4 and 1 (each within the scatter of the next); then compound 3.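

Within the data shown here, with the halogen held as bromine, the position of the bromine now carries a step of its own in this assay, a number 21 percentage points lower from compound 3 to compound 4 (beyond the scatter), which the earlier pairs could not isolate as they changed halogen and position together. Among the 4-halophenyl compounds the halogen leaves the numbers level, with no change at the digits printed from compound 2 to compound 4 (within the scatter) and a number 5 percentage points lower from compound 1 to compound 4 (within the scatter), so of the four compounds only the one with the 3-bromophenyl stands apart. No measurement at hand accounts for this dependence on where the bromine sits.

Open, as far as these compounds go, is whether a methoxy group, a nitrile, an amine or a carboxylic acid in place of the bromine of the 3-bromophenyl would keep the higher number. The read-out at one concentration also gives no potency for any of these compounds.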